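Swapping Methylsulfanyl for Ethyl on the Five-Membered Ring

The source may hold more compounds than are shown below. What is called first, only, known or untested is meant among the compounds shown, and "the series" means these compounds.

Three compounds have been measured in a functional assay on the whole organism (6C3HED cells, Mus musculus) for inhibition, at a dose of 300 mg/kg by the oral route; on this read-out lower numbers stand for less inhibition and higher numbers for more inhibition at the one dose given (going by the name of the read-out):
Compound 1 `O=C(Nc1ccc(Cl)cc1)NS(=O)(=O)c1ccc(Cl)s1` gives 89%.
Compound 2 `COc1ccc(S(=O)(=O)NC(=O)Nc2ccc(Cl)cc2)s1` gives 100%.
Compound 3 `CSc1ccc(S(=O)(=O)NC(=O)Nc2ccc(Cl)cc2)s1` gives 62%.

Compound 3 therefore stands lowest of the three, and both steps that reach it go downward: a number 27 percentage points lower from compound 1 to compound 3 (beyond the scatter) and a number 38 percentage points lower from compound 2 to compound 3 (beyond the scatter). Compound 4 `CCc1ccc(S(=O)(=O)NC(=O)Nc2ccc(Cl)cc2)s1` differs from compound 3 in one place: ethyl in place of methylsulfanyl on an aromatic carbon. For the measured compounds named here, no measured pair contains ethyl, so only these two steps bear on the change, and they say that methylsulfanyl sits at the bottom. Moving away from it in this assay is expected to give a modest rise, or none beyond the scatter. Compound 4 is estimated at 75%, within 50% to 100%. The expected step is a number 13 percentage points higher from compound 3 to compound 4 (beyond the scatter).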

Compound 4, a percentage reported as inhibition, in the whole organism at one dose (the size of the read-out at that dose, not a potency): 89%
For compound 4 the middle estimate is 14 percentage points below the measured one, and the stated range covers the measured number.
By their numbers in this assay, from the lowest: compound 3; then compounds 1 and 4 (each within the scatter of the next); then compound 2.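

In this assay, the ethyl group on this aromatic carbon next to the ring sulfur brings a clear recovery from methylsulfanyl (a number 27 percentage points higher from compound 3 to compound 4 (beyond the scatter)), so a two-atom group at this place need not give the low number. The ethyl group also matches chloro (no change at the digits printed from compound 1 to compound 4 (within the scatter)) but does not reach methoxy (a number 11 percentage points lower from compound 2 to compound 4 (beyond the scatter)). No measured evidence here explains these differences.

On these data alone, whether a longer chain such as propyl, or an amine, would fit this carbon as well as ethyl remains open.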